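A few compounds are considered here, and "the series" means these few. Any claim that something is new, unique, unknown or untested is made for them only; others in the source may bear on it.

Three compounds of the series have numbers in a functional assay on BT-549 cells (Homo sapiens) for inhibition, read by sulforhodamine B assay, with a stated time of 48 h, tested at 10 uM; a lower number here means less inhibition, a higher number more inhibition at the concentration tested (going by the name of the read-out). Compound 1 `COc1ccc(-c2cn3ccnc3c(-c3ccc4ncn(C5CCCCC5)c4c3)n2)cc1` gives 68.9% in this assay; compound 2 `O=Cc1ccc(-c2cn3ccnc3c(-c3ccc4ncn(C5CCCCC5)c4c3)n2)cc1` gives 33.8%; compound 3 `CC(=O)c1ccc(-c2cn3ccnc3c(-c3ccc4ncn(C5CCCCC5)c4c3)n2)cc1` gives 4.68%. Compound 3 therefore stands lowest of the three: its nearest neighbour is compound 2, a number 29.1 percentage points lower from compound 2 to compound 3 (beyond the scatter), and its furthest is compound 1, a number 64.2 percentage points lower from compound 1 to compound 3 (beyond the scatter). Going by the values given here, the single step that reaches compound 2 is a number 35.1 percentage points lower from compound 1 to compound 2 (beyond the scatter), so both compounds carrying a carbonyl group sit well below compound 1.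

Compound 4 `Brc1ccc(-c2cn3ccnc3c(-c3ccc4ncn(C5CCCCC5)c4c3)n2)cc1` is not yet measured. The change is bromo in place of acetyl on an aromatic carbon. The acetyl leaves, a bromo with no hydrogen-bond acceptor enters, at the same aromatic carbon of the six-membered aromatic ring of carbon only, para to a large group. Among the compounds with values here, no measured step exchanges a carbonyl group for a halogen, so the bearing of the known steps is indirect: the two large downward steps went with introducing a carbonyl group, and the modest one with enlarging it. Removing the carbonyl group in compound 4 is therefore expected to move the number upward, with the size uncertain: the step of a number 35.3 percentage points higher from compound 3 to compound 4 (beyond the scatter) is estimated as beyond the scatter. Compound 4 is expected to give 40%, in the range 10% to 70%.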

Compound 4, a percentage reported as inhibition, at one concentration (the size of the read-out at that concentration, not a potency): 35.1%
For compound 4 the middle estimate is 4.9 percentage points above the measured one; the range from low to high includes it.
By their numbers in this assay, from the lowest: compound 3; then compounds 2 and 4 (each within the scatter of the next); then compound 1.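

Replacing the acetyl with bromo at this aromatic carbon, para to a large group, gives a number 30.4 percentage points higher from compound 3 to compound 4 (beyond the scatter) in this assay, but this does not restore the level of the methoxy compound: the comparison with the methoxy group reads a number 33.8 percentage points lower from compound 1 to compound 4 (beyond the scatter). Going by these compounds alone, a carbonyl group alone therefore does not separate the low numbers from the high one, since bromo and formyl cannot be told apart, with a number 1.3 percentage points higher from compound 2 to compound 4 (within the scatter), and the acetyl of compound 3 remains the only group here whose number lies beyond the scatter from all the others. No supporting measurement is available to explain these differences.

Left open is whether the higher number of compound 1 is particular to methoxy or would extend to ethoxy, hydroxyl, an amine or a carboxylic acid at the same carbon, and whether fluoro or chloro would track with bromo. These numbers also describe the size of the read-out at one concentration, so the compounds shown leave open whether the same order would hold across a range of concentrations.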